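Ester amides: sec-butyl replacing methyl on two cores

This account rests on a few compounds, and the source may have more. Where it says the series, first, only, none or still open, it means among the compounds named here.

Compound 1 `COC(=O)[C@H](C)NC(=O)c1ccc(Oc2nc3ccccc3nc2C)cc1` gives 32200 nM in a functional assay on HeLa cells (Homo sapiens) for antiproliferative activity, read by MTT assay, with a stated time of 48 h; a lower number here means a stronger inhibitor, a higher number a weaker inhibitor. Within the data shown here, compound 2 `CC[C@@H](C)[C@H](NC(=O)c1ccc(Oc2nc3ccccc3nc2C)cc1)C(=O)OC` gives > 50000 nM in this assay, which is a limit of the assay rather than a number; it is the single reading at the limit of > 50000 nM in this assay, at which 1 of the 3 values shown sits. The change between them is sec-butyl in place of methyl on a saturated chain carbon bound to an amide-type nitrogen and a carbonyl carbon, and the step is an at least 1.5-fold higher number from compound 1 to compound 2 (0.19 log units; that floor lies within the scatter). Compound 3 `COC(=O)[C@H](C)NC(=O)c1ccc(Oc2nc3ccccc3nc2NC(C)(C)C)cc1` gives 55200 nM in this assay; its core differs from that of compound 1 by (tert-butyl)amino in place of methyl on an aromatic carbon, a step of a 1.7-fold higher number from compound 1 to compound 3 (0.23 log units; within the scatter). Compound 4 `CC[C@@H](C)[C@H](NC(=O)c1ccc(Oc2nc3ccccc3nc2NC(C)(C)C)cc1)C(=O)OC` differs from compound 3 by sec-butyl in place of methyl on a saturated chain carbon bound to an amide-type nitrogen and a carbonyl carbon, the same change as from compound 1 to compound 2, at the same place. The expected step is a 1.6-fold higher number from compound 3 to compound 4 (0.21 log units; within the scatter), resting on an at least 1.5-fold higher number from compound 1 to compound 2 (0.19 log units; that floor lies within the scatter), which itself only sets a floor. Compound 4 is therefore estimated at 90000 nM, within 45000 nM to 200000 nM, most likely reported as a limit.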

Compound 4, half-maximal inhibitory concentration: 31900 nM
Beside the measured number, compound 4's estimate is 2.8-fold (0.45 log units) above it; measured number below the stated range.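

On the core of compound 3, sec-butyl in place of methyl gives a 1.7-fold lower number from compound 3 to compound 4 (0.24 log units; within the scatter) in this assay, so this series neither confirms nor rules out that the change carries from one core to the other. Beside the step on the core of compound 1, the two readings cannot be separated: the same change on two cores in this assay, an at least 1.5-fold higher number (0.19 log units; that floor lies within the scatter) from compound 1 to compound 2 and a 1.7-fold lower number (0.24 log units; within the scatter) from compound 3 to compound 4; the limit leaves it open whether they differ. The reverse reading, (tert-butyl)amino in place of methyl, gives an at least 1.5-fold lower number from compound 2 to compound 4 (0.19 log units; that floor lies within the scatter), and it too stays unresolved: the same change on two cores in this assay, a 1.7-fold higher number (0.23 log units; within the scatter) from compound 1 to compound 3 and an at least 1.5-fold lower number (0.19 log units; that floor lies within the scatter) from compound 2 to compound 4; the limit leaves it open whether they differ.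

The compounds shown leave open whether any change at either place moves the reading in this assay beyond the scatter. A carboxylic acid in place of the methyl ester, or a benzyl group in place of sec-butyl, remains an open question.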